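From Compound 1 to the Unmethylated Piperidine of Compound 3

The compounds below may be only part of what the source reports. "The series", "measured", "known", "first", "only" and "open" are said of these compounds alone.

Compound 1 `Cc1cc(C)cc(-c2c(O)nc3cc(Cl)c([N+](=O)[O-])cc3c2OCCC2CCCCN2C)c1` gives 32 nM in an assay on cell membranes for binding affinity to Gonadotropin-releasing hormone receptor (Rattus norvegicus), read by radioligand binding (on this read-out higher numbers stand for weaker inhibition and lower numbers for stronger inhibition), the lower of the two numbers recorded; compound 2 `Cc1cc(C)cc(-c2c(O)nc3cc(Cl)c([N+](=O)[O-])cc3c2OCC[C@H]2CCCCN2C)c1` gives 85 nM in this assay. For the measured compounds named here, the step of a 2.7-fold higher number from compound 1 to compound 2 (0.42 log units; beyond the scatter) is the only measured step, and it goes together with the fact that one of compounds 1 and 2 is drawn with a defined configuration and the other without, at the place where they differ. Compound 3 `Cc1cc(C)cc(-c2c(O)nc3cc(Cl)c([N+](=O)[O-])cc3c2OCC[C@H]2CCCCN2)c1` carries the change (piperidin-2-yl in place of 1-methylpiperidin-2-yl on a saturated chain carbon, two bonds along the chain from an oxygen on an aromatic ring), and it also shares the drawn configuration of compound 2. Going by the values given here, the measured step from compound 1 to compound 2 thus bears on part of this change, and its modest size suggests that compound 3 should begin near the level of compound 2; the removal of the methyl itself has no counterpart among the measured compounds, so its effect remains open. A modest rise in the number, a 2.5-fold higher number from compound 1 to compound 3 (0.40 log units; beyond the scatter), is therefore expected for compound 3. Compound 3 is estimated at 80 nM, with a range from 20 nM to 320 nM.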

Compound 3, half-maximal inhibitory concentration: 150 nM
Compound 3: the middle estimate sits 1.9-fold (0.27 log units) below what was measured; the range from low to high includes it.
By their numbers in this assay, from the lowest: compound 1; then compounds 2 and 3 (each within the scatter of the next).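

In this assay, with the drawn configuration held the same, hydrogen in place of methyl on the amine nitrogen in the ring gives a 1.8-fold higher number from compound 2 to compound 3 (0.25 log units; within the scatter). The methyl on that nitrogen is therefore not shown to matter at this position, as the step cannot be told apart from repeated measurement. The wider step, a 4.7-fold higher number from compound 1 to compound 3 (0.67 log units; beyond the scatter), holds more than the methyl, and its size cannot be assigned to the methyl alone: the fact that one of compounds 1 and 2 is drawn with a defined configuration and the other without, at the place where they differ

Going by these compounds, what stays open is whether an ethyl or benzyl group on the same nitrogen would keep the number at this level, since only hydrogen and methyl are compared there. Also open, on these data alone, is how the opposite configuration at the ring carbon would read, with either methyl or hydrogen on the nitrogen.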